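The compounds below may be only part of what the source reports. "The series", "measured", "known", "first", "only" and "open" are said of these compounds alone.

Compounds measured in an assay on isolated protein for inhibition of matrix metalloproteinase-9 (Homo sapiens); on this read-out higher numbers stand for weaker inhibition and lower numbers for stronger inhibition:
- compound 1 `C=C[C@@H]1OC(c2ccc(-c3ccccc3)cc2)=N[C@H]1Sc1ccccc1` — compound 1 gives > 100000 nM, a limit of the assay.
- compound 2 `C=C[C@@H]1OC(c2ccc(Br)cc2)=N[C@H]1Sc1ccccc1` — compound 2 gives 94000 nM.

For the measured compounds named here, compound 2 holds the only number in this assay; the other value is a limit, (the limit of > 100000 nM in this assay, at which 1 of the 2 values shown sits). Going by the values given here, the one measured step, an at least 1.0-fold lower number from compound 1 to compound 2 (0.02 log units; that floor lies within the scatter), bromo in place of phenyl on an aromatic carbon, is within the scatter.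

Compound 3 `C=C[C@@H]1OC(c2ccc(Br)cc2)=N[C@H]1S` differs from compound 2 by hydrogen in place of phenyl on a sulfur. Among the compounds with values here, no measured step touches the sulfur, so nothing measured bears on this change. Compound 3 is expected, from compound 2 at 94000 nM, to give 25000 nM, range 3000 nM to 100000 nM. The step of a 3.8-fold lower number from compound 2 to compound 3 (0.58 log units; beyond the scatter) is an estimate only.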

Compound 3, inhibition constant: > 100000 nM
Compound 3: only a limit was reported; the forecaster's own chance of this, stated with the estimate: 20%; at least 4.0-fold (0.60 log units) between middle value and limit.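

In this assay compound 3 gives > 100000 nM, a limit of the assay. Hydrogen in place of phenyl on the sulfur gives an at least 1.0-fold higher number from compound 2 to compound 3 (0.02 log units; that floor lies within the scatter), so removing the phenyl at this position brings no stronger inhibition, while the true size of the change stays unread. The read-out leaves little room in this series: the limit of > 100000 nM in this assay, at which 2 of the 3 values shown sit.

Still open, on these data alone, is whether another group on the sulfur, such as benzyl, an amine or a longer chain ending in a carboxylic acid, gives a number beyond the scatter from compound 2.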